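Replacing 4-nitrophenyl with 3-bromo-4-methoxyphenyl in compound 3

The compounds below may be only part of what the source reports. "The series", "measured", "known", "first", "only" and "open" are said of these compounds alone.

Three related compounds have been measured so far in a functional assay on PC-3 cells (Homo sapiens) for inhibition, read by MTT assay, with a stated time of 48 h, tested at 10 uM; on this read-out higher numbers stand for more inhibition of growth at the one concentration tested and lower numbers for less inhibition of growth. Compound 1 `Cc1cc(=O)c2c(O)c(CN3CCC(Cc4ccccc4)CC3)c(O)c([C@H]3CCN(C)C[C@H]3O)c2o1` gives 16%. Compound 2 `Cc1cc(=O)c2c(O)c(CN3CCCCC3)c(O)c([C@H]3CCN(C)C[C@H]3O)c2o1` gives 14%. Compound 3 `Cc1oc2c([C@H]3CCN(C)C[C@H]3O)c(O)cc(O)c2c(=O)c1C(O)c1ccc([N+](=O)[O-])cc1` gives 24%, a number within the usual scatter of the other two, so these three cannot be ranked against one another.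

The next compound to be measured is compound 4 `COc1ccc(C(O)c2c(C)oc3c([C@H]4CCN(C)C[C@H]4O)c(O)cc(O)c3c2=O)cc1Br`, which differs from compound 3 in one aromatic group: 3-bromo-4-methoxyphenyl in place of 4-nitrophenyl on a saturated chain carbon bound to an aromatic carbon and an oxygen on a saturated carbon. Put simply, 3-bromo-4-methoxyphenyl stands in place of 4-nitrophenyl on a saturated chain carbon bound to an aromatic carbon and an oxygen on a saturated carbon.

Among the measured compounds shown here, only one measured step involves a single structural change: a number 2 percentage points lower from compound 1 to compound 2 (within the scatter). That change is hydrogen in place of benzyl on a saturated ring carbon, which is not the change made here, so it offers only indirect guidance. For the measured compounds named here, no measured pair tests a replacement of the 4-nitrophenyl group. Going by the values given here, with that one small step from compound 1 to compound 2 as the only guide, no shift beyond the scatter is expected, although the uncertainty is wide.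

The expected change is a number 2 percentage points lower from compound 3 to compound 4 (within the scatter). For compound 4, the estimated value is 22%, with an expected range of 8% to 40%.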

Compound 4, percent growth inhibition at one concentration: 0%
Compound 4: the middle estimate sits 22 percentage points above what was measured, outside the stated range (below it).
By their numbers in this assay, from the lowest: compound 4; then compounds 2, 1 and 3 (each within the scatter of the next).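

In this assay, among the compounds shown here, the aromatic group on this saturated chain carbon, bound to an aromatic carbon and an oxygen, proves able to change the result: putting 3-bromo-4-methoxyphenyl in place of 4-nitrophenyl gives a number 24 percentage points lower from compound 3 to compound 4 (beyond the scatter) and is the first single change to go beyond the scatter. The earlier step, which replaced benzyl with hydrogen on a saturated ring carbon in a different part of the molecule, stayed within the scatter, so it gave no sign that a single change could matter this much. The two aromatic groups have the same number of heavy atoms and each holds one six-membered aromatic ring of carbon only, so the step comes from a swap of the groups on that ring, and nothing measured here gives a reason for its size.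

Several things changed at once, so it stays open whether the bromine, the methoxy or the loss of the nitro group carries the step, and a plain phenyl, a 4-methoxyphenyl or a 3-bromophenyl at this place would begin to separate them. A 4-aminophenyl would further show whether the nitrogen of the departing group matters.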